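The compounds below may be only part of what the source reports. "The series", "measured", "known", "first", "only" and "open" are said of these compounds alone.

Working notes on the series.

Compound 1 `Nc1n[nH]c2cc(-c3ccc(=O)n(Cc4cccc(Cl)c4)c3)ccc12` is the reference. In an assay for inhibition of MAP kinase-interacting serine/threonine-protein kinase 1 (Homo sapiens), read by luminescence and ADP-Glo, with a stated time of 2 h (on this read-out higher numbers stand for weaker inhibition and lower numbers for stronger inhibition), compound 1 gives 11 nM, the lowest of the two numbers in hand. Among the compounds with values here, compound 3 `O=c1ccc(-c2ccc3cn[nH]c3c2)cn1Cc1cccc(Cl)c1` lacks the amino group on the core and gives 37 nM; the step of a 3.4-fold higher number from compound 1 to compound 3 (0.53 log units; beyond the scatter) is the only single-point change measured so far. Compound 2 `O=c1ccc(-c2ccc3cc[nH]c3c2)cn1Cc1ccccc1` carries a benzyl group, a different core and no amino group, and in this assay compound 2 reaches only a limit, > 2000 nM. That value is a limit, not a number (the limit of > 2000 nM in this assay, at which 1 of the 3 values shown sits), and since compound 2 differs from compound 1 in more than one place it gives no isolated reading on the benzyl change.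

Compound 4 `Nc1n[nH]c2cc(-c3ccc(=O)n(Cc4ccccc4)c3)ccc12` is the next target; it differs from compound 1 by hydrogen in place of chloro on an aromatic carbon. Within the data shown here, no measured step removes the chloro alone. The amino removal a 3.4-fold higher number from compound 1 to compound 3 (0.53 log units; beyond the scatter) shows that a single small change in this series can shift the value beyond the scatter, and compound 2, without chloro, sits at the limit. A modest rise in this assay is therefore expected for compound 4, a 2.7-fold higher number from compound 1 to compound 4 (0.44 log units; beyond the scatter). The estimate for compound 4 in this assay is 30 nM, with a range from 10 nM to 90 nM.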

Compound 4, half-maximal inhibitory concentration: 79 nM
Compound 4: the middle estimate sits 2.6-fold (0.42 log units) below what was measured; measured number inside the range.
By their numbers in this assay, from the lowest: compound 1; then compound 3; then compound 4. At a limit, above all of these: compound 2.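

Within the data shown here, removing the chloro from the 3-chlorobenzyl group gives the first isolated reading at this position: in this assay, the change gives a 7.2-fold higher number from compound 1 to compound 4 (0.86 log units; beyond the scatter). The chloro therefore counts on its own with the amino group in place on the shared core, so both ends of compound 1 now have a single-point step beyond the scatter, the other being a 3.4-fold higher number from compound 1 to compound 3 (0.53 log units; beyond the scatter). Compound 2 also lacks the chloro, but it differs from compound 1 in more than one place and its value is a limit: the limit of > 2000 nM in this assay, at which 1 of the 4 values shown sits.

Going by these compounds, whether fluoro, methyl or methoxy at this place on the aromatic ring would match the chloro stays open, as does the effect of the chloro at another place on that ring. Also open, on these data alone, is what removing the chloro and the amino together does on the core of compound 1.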